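This account rests on a few compounds, and the source may have more. Where it says the series, first, only, none or still open, it means among the compounds named here.

Measured so far in an ADME assay on Vero cells (Chlorocebus sabaeus) for cytotoxicity, with a stated time of 7 days; a lower number here means that less compound is tolerated, a higher number that more compound is tolerated:
- compound 1 `COc1cccc(CN2C(=O)CN(C(=O)c3cc4cc(OC)ccc4[nH]3)C[C@@H]2COCc2ccccc2)c1`: > 10000 nM
- compound 2 `COc1ccc2[nH]c(C(=O)N3CC(=O)N(Cc4ccccc4)[C@@H](CN4CCC(C)CC4)C3)cc2c1`: > 30000 nM
- compound 3 `O=C(c1cc2cc(C3CC3)ccc2[nH]1)N1CC(=O)N(Cc2ccccc2)[C@@H](CN2CCC(F)CC2)C1`: 24500 nM

In this assay compound 1 gives > 10000 nM, which is a limit of the assay rather than a number. Compound 2 gives > 30000 nM, likewise a limit. Among the compounds with values here, compound 3 is the only one with a number, 24500 nM. Compound 2 therefore stands at a limit, (the limit of > 30000 nM in this assay, at which 1 of the 3 values shown sits), and its position relative to compound 1 cannot be fixed beyond what the limit of > 10000 nM in this assay, at which 1 of the 3 values shown sits, shows. Within the data shown here, no pair of measured compounds differs in a single place, so no measured step is available.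

Compound 4 `COc1ccc2[nH]c(C(=O)N3CC(=O)N(Cc4ccccc4)[C@@H](CN4C(=O)c5ccccc5C4=O)C3)cc2c1` differs from compound 2 by a group of 11 heavy atoms (8 carbon, 1 nitrogen, 2 oxygen; one five-membered non-aromatic ring with 1 hetero atom, one six-membered aromatic ring of carbon only) in place of a group of 7 heavy atoms (6 carbon, 1 nitrogen; one six-membered non-aromatic ring with 1 hetero atom), on a saturated chain carbon bound to a saturated ring carbon. Among the measured compounds shown here, with compound 2 at a limit and the three values shown all sitting high in this assay, no direction for the step is supported; a step of a number no higher from compound 2 to compound 4 (the limit leaves the size open) is expected, meaning none beyond the scatter. For compound 4 the expected value in this assay is 30000 nM, with a range of 10000 nM to 100000 nM, most likely reported again as a limit.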

Compound 4, half-maximal cytotoxic concentration: 41000 nM
Estimate against measurement, compound 4: 1.4-fold (0.14 log units) below, within the range that was stated.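

No step from compound 2 to compound 4 can be read in this assay, because compound 2 stands at a limit of the assay and not at a number: the limit of > 30000 nM in this assay, at which 1 of the 4 values shown sits.

The compounds shown leave open whether the group in compound 4, in place of the 4-methylpiperidin-1-yl of compound 2, shifts the tolerated concentration at all.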